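This account rests on a few compounds, and the source may have more. Where it says the series, first, only, none or still open, it means among the compounds named here.

Measured so far in a functional assay on L1210 cells (Mus musculus) for inhibition; on this read-out lower numbers stand for stronger inhibition and higher numbers for weaker inhibition:

Compound 1, `O=C1/C(=C/c2ccc(Br)cc2)Cc2ccccc21`, gives 64800 nM.
Compound 2, `Cc1ccc(/C=C2\Cc3ccccc3C2=O)cc1`, gives 59100 nM.
Compound 3, `O=C1CCCCC/C1=C\c1ccc(Br)cc1`, gives 68400 nM.

Compound 1 and compound 2 share one core and differ in a single spot: methyl in place of bromo on an aromatic carbon. The step this change made is a 1.1-fold lower number from compound 1 to compound 2 (0.04 log units; within the scatter), so the two numbers lie within the scatter of one another and cannot be told apart.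

Compound 3 carries a different core, and how its core differs from that of compound 1 is not broken down here. Its value in this assay and that of compound 1 lie within the scatter of each other.

Compound 4, `Cc1ccc(/C=C2\CCCCCC2=O)cc1`, is not yet measured. It stands to compound 3 as compound 2 stands to compound 1: methyl in place of bromo on an aromatic carbon. The surroundings are not identical, since in compound 1 the changed carbon is para to a large group, while in compound 3 it is para to a group of 9 heavy atoms, so this is the same kind of change rather than the same change.

The step expected here is a 1.1-fold lower number from compound 3 to compound 4 (0.04 log units; within the scatter). This expectation rests on the measured step of a 1.1-fold lower number from compound 1 to compound 2 (0.04 log units; within the scatter), which was within the scatter. Compound 4 is therefore estimated at 62000 nM, with a range from 30000 nM to 125000 nM.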

Compound 4, half-maximal inhibitory concentration: > 500000 nM
Compound 4: no number, only a limit (the forecaster's own chance of this, stated with the estimate: 5%); at least 8.0-fold (0.90 log units) between middle value and limit.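

In this assay compound 4 gives > 500000 nM, which is a limit of the assay and not a number. With methyl in place of bromo, one core shows an at least 7.3-fold higher number from compound 3 to compound 4 (0.86 log units; beyond the scatter), while the other shows a 1.1-fold lower number from compound 1 to compound 2 (0.04 log units; within the scatter), so in this series the size of the step measured on one core did not carry over to the other: the same change on two cores in this assay, a 1.1-fold lower number (0.04 log units; within the scatter) from compound 1 to compound 2 and an at least 7.3-fold higher number (0.86 log units; beyond the scatter) from compound 3 to compound 4, at least 8.0-fold (0.90 log units) apart, beyond the scatter of two such steps. These two pairs show that the effect of this change depends on the core it sits on, but they do not give the reason for the difference or its full size, since the step to compound 4 is bounded only from one side: the limit of > 500000 nM in this assay, at which 1 of the 4 values shown sits.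

The compounds shown cover just two cores and just two groups on this aromatic carbon, so two pairs cannot say how the change would behave on any further core. On these data alone, whether a chloro, a methoxy or an amine in the same place would give values close to that of compound 3 or would also reach the limit, as compound 4 does, remains open.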